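Fluoro to butyl on the aryl hydrazone: compound 3

The compounds below may be only part of what the source reports. "The series", "measured", "known", "first", "only" and "open" are said of these compounds alone.

Measured so far:
Compound 1, `CC1CC/C(=N\Nc2ccccc2)c2ncc(CC(=O)O)c(=O)n21` — 430000 nM
Compound 2, `CC1CC/C(=N\Nc2ccc(F)cc2)c2ncc(C(=O)O)c(=O)n21` — 1200 nM

Two compounds of the series carry numbers in a functional assay (mast cells) for inhibition, with Rattus norvegicus as the target; on this read-out lower numbers stand for an effect already at smaller amounts and higher numbers for an effect only at larger amounts of compound. Compound 1 gives 430000 nM in this assay. Compound 2 gives 1200 nM in this assay and so stands at the lower of the two numbers, well apart from compound 1. Compound 1 and compound 2 differ in more than one place, so the gap between them is taken as it is, without being traced to a single change.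

Compound 3, `CCCCc1ccc(N/N=C2\CCC(C)n3c2ncc(C(=O)O)c3=O)cc1`, is the next case and has no number yet. It departs from compound 2 by butyl in place of fluoro on an aromatic carbon. Among the measured compounds shown here, no step between two measured compounds covers such a change, and no second pair shows how this assay answers to a change at that place on the aryl ring. What is expected for compound 3 therefore rests on compound 2 alone and carries a wide range.

The step of a 1.3-fold higher number from compound 2 to compound 3 (0.10 log units; within the scatter) is expected to be small, within the usual scatter, with no firm direction. For compound 3 the estimate in this assay is 1500 nM, between 300 nM and 8000 nM.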

Compound 3, half-maximal effective concentration: 1700 nM
For compound 3 the middle estimate is 1.1-fold (0.05 log units) below the measured one, and the stated range covers the measured number.
By their numbers in this assay, from the lowest: compounds 2 and 3 (each within the scatter of the next); then compound 1.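

In this assay, among the compounds shown here, butyl in place of fluoro on an aromatic carbon gives a 1.4-fold higher number from compound 2 to compound 3 (0.15 log units; within the scatter), and this is the first change that can be read at a single place. At this carbon, para to a large group, the number therefore does not separate fluoro from butyl, even though butyl brings 4 heavy atoms where fluoro has 1, something the earlier comparison, with its differences in more than one place, could not show. Nothing available on these compounds accounts for this result.

The compounds shown leave open whether an amine, a hydroxyl or a longer chain such as octyl at the same carbon would also stay with compound 2 and compound 3 or would move the number beyond the scatter. Also open, on these data alone, is how a carboxymethyl group in place of the carboxylic acid on the shared core would read with the fluoro or butyl aryl ring held fixed, a single change that would show what that side of the molecule contributes on its own.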